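The source may hold more compounds than are shown below. What is called first, only, known or untested is meant among the compounds shown, and "the series" means these compounds.

Compound 1 `COc1ccc(-n2cc(CN3C(=O)C[C@@H]4CC[C@@]3(C)C4(C)C)nn2)cc1` gives 100 nM in a functional assay on HepG2 cells (Homo sapiens) for inhibition, read by MTT assay, with a stated time of 24 h (a lower number here means a stronger inhibitor, a higher number a weaker inhibitor), the highest of the three numbers measured, with compound 2 `CC1(C)[C@H]2CC[C@]1(C)N(Cc1cn(-c3ccccc3)nn1)C(=O)C2` at 90 nM and compound 3 `CC1(C)[C@H]2CC[C@]1(C)N(Cc1cn(-c3cccc(F)c3)nn1)C(=O)C2` at 80 nM close by. Every measured step is small: a 1.1-fold lower number from compound 1 to compound 2 (0.05 log units; within the scatter), a 1.3-fold lower number from compound 1 to compound 3 (0.10 log units; within the scatter) and a 1.1-fold lower number from compound 2 to compound 3 (0.05 log units; within the scatter). Compound 4 `COc1cccc(-n2cc(CN3C(=O)C[C@@H]4CC[C@@]3(C)C4(C)C)nn2)c1` differs from compound 1 by 3-methoxyphenyl in place of 4-methoxyphenyl on an aromatic nitrogen. The step from compound 1 to compound 3, which also replaced the 4-methoxyphenyl, and the step from compound 2 to compound 3, which altered the same phenyl ring, both stayed within the scatter, so nothing in this series points to a shift beyond it in this assay. For compound 4 the expected value is 90 nM, in a range from 45 nM to 180 nM, meaning an expected step of a 1.1-fold lower number from compound 1 to compound 4 (0.05 log units; within the scatter).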

Compound 4, half-maximal inhibitory concentration: 70 nM
The estimate for compound 4 lay 1.3-fold (0.11 log units) above the measured number; the range from low to high includes it.
By their numbers in this assay, from the lowest: compounds 4, 3, 2 and 1 (each within the scatter of the next).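

Exchanging 4-methoxyphenyl for 3-methoxyphenyl on the aromatic nitrogen gives a 1.4-fold lower number from compound 1 to compound 4 (0.15 log units; within the scatter) and so does not separate the two methoxy isomers in this assay. Methoxy in place of fluoro gives a 1.1-fold lower number from compound 3 to compound 4 (0.06 log units; within the scatter) and methoxy in place of hydrogen gives a 1.3-fold lower number from compound 2 to compound 4 (0.11 log units; within the scatter) so hydrogen, fluoro and methoxy on this phenyl ring cannot be told apart in these compounds. No measurement shown here accounts for these numbers.

From the compounds shown here alone, whether an amine or a carboxylic acid on this phenyl ring would give a step beyond the scatter remains open. So does the effect of changing the shared core.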